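The source may report more compounds than this note shows. Statements on the series, on what has been measured and on what is new or still open speak of the compounds shown alone.

Measured in a functional assay on the whole organism with Rattus norvegicus as the target; on this read-out higher numbers stand for an effect only at larger amounts of compound and lower numbers for an effect already at smaller amounts:
- Compound 1 `CCOC(=O)C(=O)Nc1cccc(OC)c1C#N`: 55.5 mg/kg
- Compound 2 `CCOC(=O)C(=O)Nc1cccc(N)c1C#N`: 0.07 mg/kg
- Compound 3 `CCCCNc1cccc(NC(=O)C(=O)OCC)c1C#N`: 0.3 mg/kg

Of these three numbers, compound 3, at 0.3 mg/kg, is the second highest, above compound 2 and below compound 1. Compound 4 `CCOC(=O)C(=O)Nc1cccc(N(C)C(C)C)c1C#N` has the same atoms joined differently, with isopropyl(methyl)amino in place of butylamino on an aromatic carbon. The closest guide is the modest change on that nitrogen, a 4.3-fold higher number from compound 2 to compound 3 (0.63 log units; beyond the scatter). The large steps of a 790-fold lower number from compound 1 to compound 2 (2.90 log units; beyond the scatter) and a 190-fold lower number from compound 1 to compound 3 (2.27 log units; beyond the scatter) concern the loss of methoxy, and compound 4 also lacks methoxy. Among the measured compounds shown here, no measured compound carries two carbon groups on that nitrogen, so a further modest rise in this assay is expected, an estimated 3.3-fold higher number from compound 3 to compound 4 (0.52 log units; beyond the scatter). For compound 4 the estimated value is 1 mg/kg, with an expected range from 0.2 mg/kg to 6 mg/kg.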

Compound 4, dose for half-maximal effect: 1.2 mg/kg
The estimate for compound 4 lay 1.2-fold (0.08 log units) below the measured number; the measured number falls inside the stated range.
By their numbers in this assay, from the lowest: compound 2; then compound 3; then compound 4; then compound 1.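

In this assay the swap of butylamino for isopropyl(methyl)amino gives a 4.0-fold higher number from compound 3 to compound 4 (0.60 log units; beyond the scatter) even though the heavy atoms stay the same and only the hydrogen-bond donor is lost, so the arrangement at this carbon matters. The same group gives a 17-fold higher number from compound 2 to compound 4 (1.23 log units; beyond the scatter) yet still keeps most of the gain over methoxy, with a 46-fold lower number from compound 1 to compound 4 (1.67 log units; beyond the scatter) as its step. Nothing available explains these differences.

From the compounds shown here alone, compound 4 changes branching and the number of carbon groups on the nitrogen together, so isopropylamino and butyl(methyl)amino remain open as ways to separate the two. Going by these compounds, whether a carboxylic acid could replace the ethyl ester also stays open.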